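The source may report more compounds than this note shows. Statements on the series, on what has been measured and on what is new or still open speak of the compounds shown alone.

Measured in an ADME assay on HFF cells (Homo sapiens) for cytotoxicity, read by MTT assay, with a stated time of 72 h; a lower number here means a stronger inhibitor, a higher number a weaker inhibitor:
compound 1 `O=C1O[C@H]([C@@H](O)Cn2cc(-c3cccc(O)c3)nn2)C(OCc2ccccc2)=C1OCc1ccccc1` — 39000 nM
compound 2 `CC(C)(C)OC(=O)N1CCN(C(=S)SCc2cn(C[C@H](O)[C@H]3OC(=O)C(OCc4ccccc4)=C3OCc3ccccc3)nn2)CC1` — 60 nM

Compound 1 gives the highest of the two numbers in this assay; compound 2 sits far lower, and the gap between them is well beyond the usual scatter. For the measured compounds named here, no pair of measured compounds differs in a single place, so the effect of a small change on the shared core is not known from these data.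

Compound 3 `O=C1O[C@H]([C@@H](O)Cn2cc(-c3cc(F)cc(F)c3)nn2)C(OCc2ccccc2)=C1OCc1ccccc1` differs from compound 1 as follows: 3,5-difluorophenyl in place of 3-hydroxyphenyl on an aromatic carbon. Going by the values given here, with no comparable step measured, only a modest step in this assay is expected from compound 1 to compound 3, a 1.6-fold lower number from compound 1 to compound 3 (0.19 log units; within the scatter), leaning toward a somewhat lower number. Compound 3 is therefore estimated at 25000 nM in this assay, within 8000 nM to 80000 nM.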

Compound 3, half-maximal inhibitory concentration: > 100000 nM
Compound 3 was reported as a limit (the forecaster's own chance of this, stated with the estimate: 15%); middle value at least 4.0-fold (0.60 log units) from the limit.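

Within this assay 3,5-difluorophenyl in place of 3-hydroxyphenyl on this aromatic carbon gives an at least 2.5-fold higher number from compound 1 to compound 3 (0.40 log units; beyond the scatter) and so shows that the group at this position can shift the reading. Compound 3 gives > 100000 nM as a limit of the assay and not a number. The step is therefore a floor and not a size: the limit of > 100000 nM in this assay, at which 1 of the 3 values shown sits.

On these data alone, the change removes the hydroxyl and adds two fluorines in one move, so it stays open which of the two matters. Plain phenyl or 3-aminophenyl at this position would help separate them.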